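Methyl for methoxy on the enone aryl of compound 3

The source may report more compounds than this note shows. Statements on the series, on what has been measured and on what is new or still open speak of the compounds shown alone.

Compound 3 `COc1ccc(/C=C/C(=O)c2cc(-c3cc(OC)c(OC)c(OC)c3)n3nc(-c4ccccc4)cc3n2)cc1` gives 16500 nM in a functional assay on MDA-MB-231 cells (Homo sapiens) for antiproliferative activity, read by MTT assay, with a stated time of 24 h (on this read-out higher numbers stand for weaker inhibition and lower numbers for stronger inhibition), the second highest of the three numbers recorded. Compound 1 `COc1cc(-c2cc(/C=C/C(=O)c3ccc(C)cc3)nc3cc(-c4ccccc4)nn23)cc(OC)c1OC` gives 23900 nM and compound 2 `COc1cc(-c2cc(/C=C/C(=O)c3ccc(C)c(C)c3)nc3cc(-c4ccccc4)nn23)cc(OC)c1OC` gives 13500 nM; the steps of a 1.4-fold lower number from compound 1 to compound 3 (0.16 log units; within the scatter) and a 1.2-fold higher number from compound 2 to compound 3 (0.09 log units; within the scatter) both stay within the scatter, as does a 1.8-fold lower number from compound 1 to compound 2 (0.25 log units; within the scatter). Compound 4 `COc1cc(-c2cc(C(=O)/C=C/c3ccc(C)cc3)nc3cc(-c4ccccc4)nn23)cc(OC)c1OC` differs from compound 3 by methyl in place of methoxy on an aromatic carbon. Within the data shown here, no measured pair carries this exact exchange; the nearest comparison is the methyl entering on an aromatic carbon in a 1.8-fold lower number from compound 1 to compound 2 (0.25 log units; within the scatter), which changed nothing beyond the scatter. The expected step is a 1.1-fold higher number from compound 3 to compound 4 (0.04 log units; within the scatter), that is, none beyond the scatter. Compound 4 is therefore estimated at 18000 nM, within 7000 nM to 45000 nM.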

Compound 4, half-maximal inhibitory concentration: 18600 nM
Compound 4: middle estimate off by 1.0-fold (0.01 log units), on the low side, and the stated range covers the measured number.
By their numbers in this assay, from the lowest: compounds 2, 3, 4 and 1 (each within the scatter of the next).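

In this assay, 4-methoxyphenyl to 4-methylphenyl, para to a large group, gives a 1.1-fold higher number from compound 3 to compound 4 (0.05 log units; within the scatter), so this position tolerates the exchange within the scatter. Among these compounds, with 4-methylphenyl kept, (2-(4-methylphenyl)ethenyl)carbonyl in place of 2-((4-methylphenyl)carbonyl)ethenyl gives a 1.3-fold lower number from compound 1 to compound 4 (0.11 log units; within the scatter), the first reading of this exchange without a change in the aryl substituent, and the step against the 3,4-dimethylphenyl analogue is a 1.4-fold higher number from compound 2 to compound 4 (0.14 log units; within the scatter). Nothing available accounts for these numbers.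

Open, on these data alone, is whether an amine or a carboxylic acid at this position would give a step beyond the scatter. A longer chain there is equally unresolved.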